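Replacing chloro with methyl in compound 2

The compounds below may be only part of what the source reports. "The series", "measured", "known", "first", "only" and "open" are said of these compounds alone.

In a functional assay on HCT-116 cells (Homo sapiens) for cytotoxicity, read by sulforhodamine B assay, with a stated time of 48 h (a higher number here means a weaker inhibitor, a lower number a stronger inhibitor), compound 2 `O=S(=O)(c1ccccc1)c1cnc2cc(-c3ccccc3)nn2c1-c1ccc(Cl)cc1` reports only a limit of > 25 ug/mL and no number. Compound 1 `O=S(=O)(c1ccccc1)c1cnc2cc(-c3ccccc3)nn2c1-c1ccccc1` gives 1.27 ug/mL with hydrogen where compound 2 has chloro. Among the compounds with values here, the one measured step bearing on the next change is an at least 19-fold higher number from compound 1 to compound 2 (1.29 log units; beyond the scatter) and it is large, beyond the scatter. Compound 3 `Cc1ccc(-c2c(S(=O)(=O)c3ccccc3)cnc3cc(-c4ccccc4)nn23)cc1` puts methyl in place of chloro on that aromatic carbon, para to a large group, as counted in methyl in place of chloro on an aromatic carbon and read as 4-chlorophenyl to 4-methylphenyl. Within the data shown here, no methyl compound has been measured, so the expectation rests on an at least 19-fold higher number from compound 1 to compound 2 (1.29 log units; beyond the scatter) alone and points part of the way back towards compound 1 at 1.27 ug/mL in this assay without reaching it. The expected move is an at least 4.1-fold lower number from compound 2 to compound 3 (0.61 log units; beyond the scatter) and it would be a clear step to a lower number. For compound 3 the estimate is 6 ug/mL with an expected range of 1.5 ug/mL to 25 ug/mL and a reading at the limit stays possible.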

Compound 3, half-maximal inhibitory concentration: 18 ug/mL
For compound 3 the middle estimate is 3.0-fold (0.48 log units) below the measured one, and the stated range covers the measured number.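

In this assay, compound 3 gives a real number for a group other than hydrogen on this aromatic carbon, and the step from hydrogen to methyl is large and beyond the scatter: a 14-fold higher number from compound 1 to compound 3 (1.15 log units; beyond the scatter). The loss seen with chloro is therefore not confined to chloro, since methyl in place of hydrogen also moves the number well away from compound 1. Whether methyl and chloro differ from each other remains unsettled, with an at least 1.3-fold lower number from compound 2 to compound 3 (0.14 log units; that floor lies within the scatter), and compound 2 stands at a limit of the assay rather than a number, which is why only a floor can be read: the limit of > 25 ug/mL in this assay, at which 1 of the 3 values shown sits.

Still open, on these data alone, is whether fluoro, methoxy, an amine or a carboxylic acid on that carbon would stay close to compound 1 at 1.27 ug/mL or move away as methyl does. As far as these compounds go, it is also open whether the same step holds on other cell lines.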